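The source may report more compounds than this note shows. Statements on the series, on what has been measured and on what is new or still open speak of the compounds shown alone.

Compound 1, `CCN(Cc1ccoc1)C(=O)COc1ccc(C)cc1`: 136 nM
Compound 2, `CCN(Cc1cccs1)C(=O)COc1ccc(C(C)C)cc1`: 397 nM
Compound 3, `Cc1ccc(OCC(=O)N(Cc2cccs2)c2c(C)n[nH]c2C)cc1`: 0.3 nM

All three were tested in an assay on HEK293 cells for agonist activity at transient receptor potential cation channel subfamily M member 8 (Homo sapiens), read by fluorescence and calcium flux, with a stated time of 15 min; a lower number here means that less compound is needed, a higher number that more compound is needed for the effect. Compound 1 stands second highest of the three numbers: compound 2 gives a higher number, beyond the scatter, while compound 3 gives a far lower one, also beyond the scatter. Compound 4, `CCN(Cc1cc[nH]c1)C(=O)COc1ccc(C)cc1`, has not yet been measured. It differs from compound 1 in one place: 1H-pyrrol-3-yl in place of furan-3-yl on a saturated chain carbon bound to an amide-type nitrogen. One hydrogen-bond acceptor leaves and one hydrogen-bond donor enters; the rest of the molecule is unchanged. Going by the values given here, no step between measured compounds shows how this assay answers such a swap, so only a modest step is expected in this assay, in either direction, likely close to the scatter. Compound 4 is therefore expected to give 200 nM, within a range of 60 nM to 700 nM. That estimate corresponds to an expected step of a 1.5-fold higher number from compound 1 to compound 4 (0.17 log units; within the scatter).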

Compound 4, half-maximal effective concentration: 21800 nM
Compound 4: middle estimate off by 110-fold (2.04 log units), on the low side; the whole stated range lies below it.
By their numbers in this assay, from the lowest: compound 3; then compound 1; then compound 2; then compound 4.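

At this position, on a saturated chain carbon bound to an amide-type nitrogen, this assay responds sharply to a swap between two rings of the same size: 1H-pyrrol-3-yl in place of furan-3-yl gives a large step (a 160-fold higher number from compound 1 to compound 4 (2.20 log units; beyond the scatter)). The exchange of one hydrogen-bond acceptor for one hydrogen-bond donor is therefore far from neutral in this pair. Nothing available explains why the number rises so steeply. On these data alone, it remains open whether 1-methyl-1H-pyrrol-3-yl, which replaces the ring nitrogen's hydrogen with methyl, would return the number towards that of compound 1.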